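This account rests on a few compounds, and the source may have more. Where it says the series, first, only, none or still open, it means among the compounds named here.

In a functional assay on COR-L23 cells (Homo sapiens) for antiproliferative activity, read by CellTiter-Glo, with a stated time of 72 h (a lower number here means a stronger inhibitor, a higher number a weaker inhibitor), compound 1 `Nc1ccc(CNC(=O)Nc2ccc(CN3C(=O)c4ccccc4C3=O)cc2)cn1` gives 3.1 nM, and compound 2 `O=C(Nc1ccc(CN2C(=O)c3ccccc3C2=O)cc1)[C@H]1C[C@@H]1c1cccnc1` gives 35 nM, the higher of the two numbers. Among the measured compounds shown here, the only measured step, an 11-fold higher number from compound 1 to compound 2 (1.05 log units; beyond the scatter), changes the same carbonyl carbon but swaps different groups, so it does not directly bear on compound 3 `O=C(Nc1ccc(CN2C(=O)c3ccccc3C2=O)cc1)N1CC(c2cccnc2)C1`. Compound 3 differs from compound 2 by a group of 10 heavy atoms (8 carbon, 2 nitrogen; one four-membered non-aromatic ring with 1 hetero atom, one six-membered aromatic ring with 1 hetero atom) in place of a group of 9 heavy atoms (8 carbon, 1 nitrogen; one three-membered non-aromatic ring of carbon only, one six-membered aromatic ring with 1 hetero atom), on a carbonyl carbon. Without a comparable measured step, only a small move, near the scatter in either direction, is expected, which amounts to a 1.4-fold higher number from compound 2 to compound 3 (0.15 log units; within the scatter). Compound 3 is estimated at 50 nM, with a range from 12 nM to 200 nM.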

Compound 3, half-maximal inhibitory concentration: 29 nM
The estimate for compound 3 lay 1.7-fold (0.24 log units) above the measured number, within the range that was stated.
By their numbers in this assay, from the lowest: compound 1; then compounds 3 and 2 (each within the scatter of the next).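

In this assay, on this carbonyl carbon, the group with a four-membered non-aromatic ring and the group with a three-membered carbon ring cannot be told apart (a 1.2-fold lower number from compound 2 to compound 3 (0.08 log units; within the scatter)). The group of compound 1 still stands apart from the four-membered ring group (a 9.4-fold higher number from compound 1 to compound 3 (0.97 log units; beyond the scatter)), as it does from the three-membered ring group. No measurement shown explains this gap. Going by these compounds, it remains open which part of the group of compound 1 accounts for the gap, and whether a pyrrolidine ring at this carbonyl carbon would also match compound 3.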